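Aryl variation on the triazole nitrogen of a kinase-type scaffold

The source may hold more compounds than are shown below. What is called first, only, known or untested is meant among the compounds shown, and "the series" means these compounds.

Measured compounds:
compound 1 `COc1cc2c(Oc3ccc(NC(=O)c4nnn(-c5ccccc5Cl)c4C(F)(F)F)cc3F)ccnc2cc1OCCCN1CCN(C)CC1`, 270 nM
compound 2 `COc1cc2c(Oc3ccc(NC(=O)c4nnn(-c5ccc(C)cc5)c4C(F)(F)F)cc3F)ccnc2cc1OCCCN1CCN(C)CC1`, 1170 nM

In a functional assay on HT-29 cells (Homo sapiens) for cytotoxicity, read by MTT assay, with a stated time of 72 h (a higher number here means a weaker inhibitor, a lower number a stronger inhibitor), compound 1 gives 270 nM and compound 2 gives 1170 nM. Compound 2 therefore stands with the highest number of the two; its nearest neighbour is compound 1, and the step of a 4.3-fold higher number from compound 1 to compound 2 (0.64 log units; beyond the scatter) separates them.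

Compound 3 `COc1cc2c(Oc3ccc(NC(=O)c4nnn(-c5ccc(F)c(F)c5)c4C(F)(F)F)cc3F)ccnc2cc1OCCCN1CCN(C)CC1` carries 3,4-difluorophenyl in place of 4-methylphenyl on an aromatic nitrogen. For the measured compounds named here, the only measured step that bears on this position is a 4.3-fold higher number from compound 1 to compound 2 (0.64 log units; beyond the scatter), which shows that exchanging the aryl group on the aromatic nitrogen moves the number by a modest amount beyond the scatter. Going by the values given here, no measured step uses a 3,4-difluorophenyl group, so the direction is open; the two aryl groups seen so far give numbers that bracket a plausible outcome. Compound 3 is expected to fall between the two measured numbers, a step of a 2.0-fold lower number from compound 2 to compound 3 (0.29 log units; within the scatter) from compound 2, with an estimated 600 nM and a range from 200 nM to 1800 nM.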

Compound 3, half-maximal inhibitory concentration: 150 nM
For compound 3 the middle estimate is 4.0-fold (0.60 log units) above the measured one; measured number outside the range, below it.
By their numbers in this assay, from the lowest: compounds 3 and 1 (each within the scatter of the next); then compound 2.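

In this assay, the aryl group on the aromatic nitrogen produces a second step beyond the scatter: a 7.8-fold lower number from compound 2 to compound 3 (0.89 log units; beyond the scatter). Measured against 2-chlorophenyl, 3,4-difluorophenyl gives a 1.8-fold lower number from compound 1 to compound 3 (0.26 log units; within the scatter), so the two halogen-bearing aryl groups cannot be separated, and compound 2, with 4-methylphenyl, stands apart from both across these three compounds. No measurement shown accounts for this separation among the aryl groups.

The steps change the identity and the placement of the aryl substituents together, and the compounds shown do not separate these two changes. Also open, on these data alone, is how the number responds to a 4-chlorophenyl or 2-methylphenyl group at this position, or to an aryl group carrying an amine or a carboxylic acid.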